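This account rests on a few compounds, and the source may have more. Where it says the series, first, only, none or still open, it means among the compounds named here.

Measured so far:
Compound 1, `CC(C)NC(=O)[C@H]1CC[C@@H](n2/c(=N/C(=O)c3ccc(F)cc3)[nH]c3ccc(CN4CCCCC4)cc32)CC1`: 302 mL.min-1.g-1
Compound 2, `CC(C)NC(=O)[C@H]1CC[C@@H](n2/c(=N/C(=O)c3cc(F)cc(Cl)c3)[nH]c3ccc(CN4CCC(C(C)(C)O)CC4)cc32)CC1`: 83 mL.min-1.g-1

Among the measured compounds shown here, in an in vitro ADME assay on microsomes from liver (Homo sapiens) for metabolic stability (on this read-out higher numbers stand for fast clearance and lower numbers for slow clearance), compound 1 stands with the higher of the two numbers known. Its nearest neighbour is compound 2, whose value in this assay is lower by a gap that exceeds the scatter of repeated measurement. For the measured compounds named here, no single-point step between these two compounds is recorded; they differ in more than one place, so only their two values speak.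

Compound 3, `CC(C)NC(=O)[C@H]1CC[C@@H](n2/c(=N/C(=O)c3ccc(F)cc3)[nH]c3ccc(CNCC(C)(C)O)cc32)CC1`, has not yet been measured. It differs from compound 1 in one place: (2-hydroxy-2-methylpropyl)amino in place of piperidin-1-yl on a saturated chain carbon bound to an aromatic carbon.

Going by the values given here, no measured pair shows this exact change, so the expectation rests on what is known. Compound 2 carries a hydroxyl-bearing group and gives 83 mL.min-1.g-1, and compound 3 likewise carries such a group. For compound 3 the step of a 2.0-fold lower number from compound 1 to compound 3 (0.30 log units; within the scatter) is therefore expected to run downward, beyond the scatter but short of the gap to compound 2. In this assay compound 3 is estimated at 150 mL.min-1.g-1, with a plausible range from 70 mL.min-1.g-1 to 300 mL.min-1.g-1.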

Compound 3, intrinsic clearance in microsomes: 233 mL.min-1.g-1
Estimate against measurement, compound 3: 1.6-fold (0.19 log units) below; the measured number falls inside the stated range.
By their numbers in this assay, from the lowest: compound 2; then compounds 3 and 1 (each within the scatter of the next).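

In this assay the exchange of piperidin-1-yl for (2-hydroxy-2-methylpropyl)amino on a saturated chain carbon bound to an aromatic carbon gives a 1.3-fold lower number from compound 1 to compound 3 (0.11 log units; within the scatter) and thus no change that can be told from the scatter. Among the compounds shown here, this is the first direct reading at this position: with the rest of compound 1 kept, the six-membered ring can give way to an open chain with a hydroxyl, and the read-out stays in the range of fast clearance set by compound 1, even though the two groups differ in their ring and in their hydrogen-bond donors and acceptors. Nothing measured on these compounds offers an explanation of this outcome. 

The number of compound 2 stays unaccounted for, as compound 2 differs from compound 1 in more than one place, so the share of its substituted piperidine and of its chloro and fluoro benzoyl group cannot be separated. As far as these compounds go, whether another amine at this position, such as morpholin-4-yl, or a shorter chain, such as (2-hydroxyethyl)amino, would move the clearance beyond the scatter also remains open.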